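The source may hold more compounds than are shown below. What is called first, only, known or untested is meant among the compounds shown, and "the series" means these compounds.

In a functional assay on L1210 cells (Mus musculus) for antiproliferative activity, read by cell counting, with a stated time of 2 days (on this read-out higher numbers stand for weaker inhibition and lower numbers for stronger inhibition), compound 1 (`CCCCN(C)c1nc(N)c(C(=O)c2cc(OC)c(OC)c(OC)c2)s1`) gives 53000 nM while compound 2 (`COc1cc(C(=O)c2sc(N3CCCC3)nc2N)cc(OC)c1OC`) gives 370 nM on the same read-out. The step between them (a 140-fold lower number from compound 1 to compound 2 (2.16 log units; beyond the scatter)) has pyrrolidin-1-yl in place of butyl(methyl)amino on an aromatic carbon, and it is large and beyond the scatter. Compound 3 (`COc1ccc(C(=O)c2sc(N3CCCC3)nc2N)cc1`) shows > 200000 nM as its entry, and that entry is only a limit, not a number.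

Compound 4 (`Nc1nc(N2CCCC2)sc1C(=O)c1ccccc1`) has not been measured. It carries hydrogen in place of methoxy on an aromatic carbon of a six-membered aromatic ring of carbon only, para to a large group (hydrogen in place of methoxy on an aromatic carbon). Within the data shown here, the one measured step concerns another group, so its size does not carry over, and no measured step removes a methoxy group. Since the entry of compound 3 at > 200000 nM is a limit, only a small move toward a lower number, if any, is expected in this assay and compound 4 may well be reported as a limit too. The expected step is an at least 1.6-fold lower number from compound 3 to compound 4 (0.22 log units; that floor lies within the scatter) in size. Compound 4 is estimated at 120000 nM with 30000 nM to 200000 nM as the expected range.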

Compound 4, half-maximal inhibitory concentration: > 200000 nM
Compound 4: no number, only a limit; the forecaster's own chance of this, stated with the estimate: 60%; middle value at least 1.6-fold (0.22 log units) away from the limit.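

No step from compound 3 to compound 4 can be read in this assay, because both entries are limits and not numbers: the limit of > 200000 nM in this assay, at which 2 of the 4 values shown sit.

The compounds shown leave open how far hydrogen in place of methoxy on an aromatic carbon moves the number in this assay, and in which direction, if it moves it at all.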